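The source may report more compounds than this note shows. Statements on the series, on what has been measured and on what is new or still open speak of the compounds shown alone.

Compound 2 `CC(C)C[C@H](N)c1cc(C(F)(F)F)ccc1N1CCN(C(=O)COc2ccc(O)cc2)CC1` gives 4600 nM in an assay on HEK293 cells for displacement of a labelled ligand from Melanocortin receptor 4 (Homo sapiens) (a higher number here means a weaker inhibitor, a lower number a stronger inhibitor), and so stands at the highest of the two numbers measured in the series; the nearest is compound 1 `CC(C)C[C@H](N)c1cc(C(F)(F)F)ccc1N1CCN(C(=O)[C@H](C)Cc2ccc(Cl)cc2)CC1`, which gives 31 nM in this assay. Among the measured compounds shown here, the one measured step that bears on the present question is a 150-fold higher number from compound 1 to compound 2 (2.17 log units; beyond the scatter), where 1-(4-chlorobenzyl)ethyl on the carbonyl carbon was replaced by (4-hydroxyphenoxy)methyl. Compound 3 `Cc1cc(CC(C)C(=O)N2CCN(c3ccc(C(F)(F)F)cc3[C@@H](N)CC(C)C)CC2)ccc1Cl` has not yet been measured. It differs from compound 2 by 1-(4-chloro-3-methylbenzyl)ethyl in place of (4-hydroxyphenoxy)methyl on a carbonyl carbon, which runs almost exactly opposite to the measured step: the group entering is the 1-(4-chlorobenzyl)ethyl of compound 1 carrying one further methyl. A large step towards a lower number is therefore expected, of about the size of a 150-fold higher number from compound 1 to compound 2 (2.17 log units; beyond the scatter) but in reverse. In this assay compound 3 is expected at 35 nM, with a range of 10 nM to 150 nM, which corresponds to an estimated 130-fold lower number from compound 2 to compound 3 (2.12 log units; beyond the scatter).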

Compound 3, inhibition constant: 71 nM
For compound 3 the middle estimate is 2.0-fold (0.31 log units) below the measured one, within the range that was stated.
By their numbers in this assay, from the lowest: compound 1; then compound 3; then compound 2.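

In this assay the step of a 65-fold lower number from compound 2 to compound 3 (1.81 log units; beyond the scatter) shows that recovery from the weak (4-hydroxyphenoxy)methyl amide is not confined to the 1-(4-chlorobenzyl)ethyl group of compound 1, since 1-(4-chloro-3-methylbenzyl)ethyl on the same carbonyl carbon also restores a low number. The added methyl is tolerated at a modest cost, seen in the step of a 2.3-fold higher number from compound 1 to compound 3 (0.36 log units; beyond the scatter) and small beside the change from the (4-hydroxyphenoxy)methyl group. No supporting data account for either step.

From the compounds shown here alone, whether an ethyl or a methoxy group in place of that added methyl would keep the number low remains open. Also open, going by these compounds, is how much of the gap to compound 1 reflects the configuration of the acyl chain, which is defined in compound 1 but not in compound 3.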